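Pentyl Ester to tert-Butyl Carbamate on a Shared Core

This account rests on a few compounds, and the source may have more. Where it says the series, first, only, none or still open, it means among the compounds named here.

Measured compounds:
compound 1 `CCCCCC(=O)OCC1CN(C(=O)c2cc(OC)c(OC)c(OC)c2)CCN1C(=O)c1cc(OC)c(OC)c(OC)c1`: 290 nM
compound 2 `CCC(CC)C(=O)OCC1CN(Cc2cc(OC)c(OC)c(OC)c2)CCN1Cc1cc(OC)c(OC)c(OC)c1`: 2700 nM

In a functional assay (Oryctolagus cuniculus) for inhibition of platelet-activating factor receptor (Cavia porcellus) (a higher number here means a weaker inhibitor, a lower number a stronger inhibitor), compound 1 gives 290 nM, the lowest of the two numbers. Compound 2 gives 2700 nM in this assay, a gap that lies beyond the scatter; compound 2 differs from compound 1 in more than one place, so no single structural step accounts for it.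

Compound 3 `COc1cc(C(=O)N2CCN(C(=O)c3cc(OC)c(OC)c(OC)c3)C(COC(=O)NC(C)(C)C)C2)cc(OC)c1OC` has not yet been measured in this assay. It differs from compound 1 in one place: (tert-butyl)amino in place of pentyl on a carbonyl carbon. Within the data shown here, no measured pair shows this change, so the expectation rests on compound 1 alone. A step of modest size is anticipated, and without a clear direction beyond the scatter, with a slight lean towards a higher number. Compound 3 is therefore expected to give about 500 nM in this assay, within a range of 150 nM to 1800 nM. This corresponds to an expected step of a 1.7-fold higher number from compound 1 to compound 3 (0.24 log units; within the scatter).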

Compound 3, half-maximal inhibitory concentration: 130 nM
Estimate against measurement, compound 3: 3.8-fold (0.59 log units) above; measured number outside the range, below it.
By their numbers in this assay, from the lowest: compound 3; then compound 1; then compound 2.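

The earlier compounds shown here offered no single-step comparison, so nothing could be said about this position on its own. Exchanging pentyl for (tert-butyl)amino on a carbonyl carbon now gives, in this assay, a 2.2-fold lower number from compound 1 to compound 3 (0.35 log units; beyond the scatter), showing that this position affects the read-out and that the carbamate is at least as well accepted here as the ester. Both groups count 5 heavy atoms, though the entering group adds 1 hydrogen-bond donor, and nothing available explains the step.

Among these compounds, the single change alters both the nitrogen and the branching of the chain, so it remains open which of these matters; a pentylamino group or a 2,2-dimethylpropyl group on the same carbonyl carbon would separate the two. Going by these compounds, whether the step carries over to the core of compound 2 also remains open.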